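The compounds below may be only part of what the source reports. "The series", "measured", "known", "first", "only" and "open" are said of these compounds alone.

Measured so far in an ADME assay on MDCK-II cells (Canis lupus familiaris) for permeability; a lower number here means that the compound crosses the layer more slowly, a higher number that the compound crosses the layer faster:
- compound 1 `CC(C)Oc1cc(Oc2ccc(S(C)(=O)=O)cc2)cc(-c2ccnc(=O)[nH]2)c1`: "not determined" (no result reported)
- compound 2 `CC(C)Oc1cc(Oc2ccc(S(C)(=O)=O)cc2)cc(-c2nccc(=O)[nH]2)c1`: 24 10^-6 cm/s
- compound 3 `CCc1cnc(-c2cc(Oc3ccc(S(C)(=O)=O)cc3)cc(OC(C)C)c2)[nH]c1=O`: 4 10^-6 cm/s

Compound 2, at 24 10^-6 cm/s, holds the higher of the two numbers in this assay, and its nearest neighbour is compound 3. Compound 1 offers no number for comparison.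

The next compound to be read is compound 4 `CC(C)Oc1cc(Oc2ccc(S(C)(=O)=O)cc2)cc(-c2ncc(Cl)c(=O)[nH]2)c1`. It differs from compound 2 as follows: chloro in place of hydrogen on an aromatic carbon. In words, this is chloro in place of hydrogen on an aromatic carbon.

Among the compounds with values here, only one measured step bears on this change. It is also a replacement of hydrogen on an aromatic carbon, with ethyl as the incoming group: a 6.0-fold lower number from compound 2 to compound 3 (0.78 log units; beyond the scatter). This single step is thin evidence and establishes no trend. Within the data shown here, no measured compound carries chloro, so the data do not show how far the ethyl result transfers.

A step in the same direction is therefore expected in this assay, though a smaller one, and a result within the scatter of compound 2 remains possible. The expected change is a 2.2-fold lower number from compound 2 to compound 4 (0.34 log units; beyond the scatter). For compound 4 the estimated value is 11 10^-6 cm/s, with an expected range from 4 10^-6 cm/s to 26 10^-6 cm/s.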

Compound 4, apparent permeability: 8.3 10^-6 cm/s
The estimate for compound 4 lay 1.3-fold (0.12 log units) above the measured number, and the stated range covers the measured number.
By their numbers in this assay, from the lowest: compound 3; then compound 4; then compound 2.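

Chloro on this aromatic carbon gives a 2.9-fold lower number from compound 2 to compound 4 (0.46 log units; beyond the scatter) in this assay and so goes the same way as ethyl, which makes two replacements of hydrogen at this position that both lower the number, with no listed compound going against that direction. The incoming group still matters, since exchanging the two substituents gives a 2.1-fold higher number from compound 3 to compound 4 (0.32 log units; beyond the scatter) and chloro therefore keeps more of the number of the unsubstituted compound 2 than ethyl does, though both substituted compounds stay below it. Nothing measured here accounts for either drop or for the gap between chloro and ethyl.

Two substituents cannot show whether the size of the drop follows any single feature of the incoming group, and an amine, a carboxylic acid, a methoxy group or a longer chain at this position could either follow the same direction or break it. The shift of the ring nitrogen in compound 1 also stays unread in this assay, as compound 1 has "not determined" (no result reported) and offers no comparison with compound 2.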